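A few compounds are considered here, and "the series" means these few. Any claim that something is new, unique, unknown or untested is made for them only; others in the source may bear on it.

Compounds measured so far:
- compound 1, `Cc1ccccc1NC(=O)N[C@H](C)c1ccccc1`, 99%
- compound 2, `C[C@@H](NC(=O)Nc1ccccc1C(F)(F)F)c1ccccc1`, 54%
- compound 3, `C[C@H](NC(=O)Nc1ccccc1C(F)(F)F)c1ccccc1`, 97%

All three were tested in an ADME assay on the whole organism with Oryza sativa as the target, tested at 10 uM; a lower number here means a stronger effect, a higher number a weaker effect of the compound at the concentration tested. Compound 2 has the lowest number of the three, that is the strongest effect: compound 3 stands a number 43 percentage points higher from compound 2 to compound 3 (beyond the scatter), and the gap to compound 1 is of similar size. Compound 2 and compound 3 share every atom and bond; the difference is the fact that compounds 2 and 3 differ only in the configuration as drawn, so the configuration alone moves the number. From compound 1 to compound 2 the change is a trifluoromethyl in place of a methyl on an aromatic carbon, and the number falls a number 45 percentage points lower from compound 1 to compound 2 (beyond the scatter).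

Compound 4, `C[C@@H](NC(=O)Nc1ccccc1F)c1ccccc1`, has not been measured. It keeps the configuration of compound 2 and differs from it by fluoro in place of trifluoromethyl on an aromatic carbon. Going by the values given here, the step that bears on this is the one from compound 1 to compound 2, which was large and in the direction of a stronger effect when the trifluoromethyl entered; compound 4 removes most of that group again, leaving a single fluorine. The expectation is therefore a move back towards the number of compound 1, estimated as a number 28 percentage points higher from compound 2 to compound 4 (beyond the scatter), beyond the scatter but not the full return. For compound 4 the estimated value is 82%, expected to lie between 58% and 100%.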

Compound 4, a percentage reported as activity, at one concentration (the size of the read-out at that concentration, not a potency): 77%
Compound 4: the middle estimate sits 5 percentage points above what was measured; measured number inside the range.
By their numbers in this assay, from the lowest: compound 2; then compound 4; then compounds 3 and 1 (each within the scatter of the next).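

In this assay, three different groups can now be compared on the same aromatic carbon with the configuration unchanged, and the outcome at this position turns out to be graded rather than all or nothing. Replacing trifluoromethyl with fluoro gives a number 23 percentage points higher from compound 2 to compound 4 (beyond the scatter), and replacing methyl with fluoro gives a number 22 percentage points lower from compound 1 to compound 4 (beyond the scatter), so the single fluorine keeps part of the effect seen with trifluoromethyl while still clearly differing from methyl. Nothing measured here explains why the three groups fall in this order.

The compounds shown leave open whether the mirror-image form of compound 4 would lose its effect, as the configuration change from compound 2 to compound 3 did for the trifluoromethyl pair. They also do not show where other groups on this aromatic carbon, such as chloro, methoxy or nitrile, would fall relative to fluoro and trifluoromethyl, or whether a group larger than trifluoromethyl would strengthen the effect further.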